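From an Ethyl Ester to a Morpholine Amide

The source may hold more compounds than are shown below. What is called first, only, known or untested is meant among the compounds shown, and "the series" means these compounds.

Of the compounds shown here, three sharing one core have been measured in a functional assay on a cell-free system (plasma, Oryctolagus cuniculus) for inhibition of platelet-activating factor acetylhydrolase (Homo sapiens), tested at 100 nM; on this read-out higher numbers stand for more inhibition at the one concentration tested (going by the name of the read-out) and lower numbers for less inhibition. Compound 1 `CCCCCCCCN(C)C(=O)Cn1cc(Cc2cnc(O)nc2)c(=O)nc1SCc1ccc(F)cc1` gives 34%. Compound 2 `CCCCCCCCCCCCN(C)C(=O)Cn1cc(Cc2cnc(=O)n(CC(=O)OCC)c2)c(=O)nc1SCc1ccc(F)cc1` gives 15%, the lowest of the three numbers. Compound 3 `CCCCCCCCN(C)C(=O)Cn1cc(Cc2cnc(=O)n(CC(=O)N3CCN(C(C)=O)CC3)c2)c(=O)nc1SCc1ccc(F)cc1` gives 49%. Compound 2 therefore stands at the bottom: its nearest neighbour is compound 1, whose number lies beyond the scatter above it, and the furthest is compound 3, also beyond the scatter.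

Compound 4 `CCCCCCCCCCCCN(C)C(=O)Cn1cc(Cc2cnc(=O)n(CC(=O)N3CCOCC3)c2)c(=O)nc1SCc1ccc(F)cc1` has not yet been measured. It differs from compound 2 in one place: morpholin-4-yl in place of ethoxy on a carbonyl carbon. For the measured compounds named here, no pair of measured compounds differs in exactly this way, so the direction of the step cannot be read off a measured precedent. What the numbers do show is that compound 2, carrying the ethoxycarbonyl group, gives 15%. Compound 3, which differs in several places from the others, gives 49%. On that footing an upward step is expected from compound 2 to compound 4 in this assay, a number 15 percentage points higher from compound 2 to compound 4 (beyond the scatter), modest rather than large. Compound 4 is estimated to give 30%, within a range from 10% to 55%.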

Compound 4, a percentage reported as inhibition, at one concentration (the size of the read-out at that concentration, not a potency): 30%
Compound 4: the middle estimate sits on the measured number at the digits printed, within the range that was stated.
By their numbers in this assay, from the lowest: compound 2; then compounds 4 and 1 (each within the scatter of the next); then compound 3.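

In this assay, the carbonyl carbon that carries the ethoxy group proves to be a place where the substituent counts: with the dodecyl chain and the rest of the molecule unchanged, morpholin-4-yl in place of ethoxy gives a number 15 percentage points higher from compound 2 to compound 4 (beyond the scatter) on this read-out. For the compounds shown here, this is the first pair in the set that differs in one place only, whereas the earlier compounds could be set side by side only across several differences at once. The step brings in a six-membered non-aromatic ring and more heavy atoms while the counts of hydrogen-bond donors and acceptors and the net charge stay the same, and nothing measured here accounts for it.

Open, from the compounds shown here alone, is whether the higher number belongs to the ring or simply to an amide in place of the ester, a question that a dimethylamino group or a piperidin-1-yl group on the same carbonyl carbon would bear on. Also open, going by these compounds, is what a carboxylic acid at this place would give, and whether the step from ethoxy to morpholin-4-yl carries over to compounds with an octyl chain.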